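From 4-bromophenyl to 3-methoxyphenyl on a shared core

The source may hold more compounds than are shown below. What is called first, only, known or untested is meant among the compounds shown, and "the series" means these compounds.

In a functional assay on HepG2 cells (Homo sapiens) for inhibition, read by MTT assay, with a stated time of 48 h (a lower number here means a stronger inhibitor of growth, a higher number a weaker inhibitor of growth), compound 1 `COc1ccc2c(c1)c(C1CC(c3ccc(F)cc3)=NN1C(=O)c1ccc(OC)nc1)cn2C` gives 220 nM. Compound 2 `COc1ccc2c(c1)c(C1CC(c3ccc(Br)cc3)=NN1C(=O)c1ccc(OC)nc1)cn2C` gives > 10000 nM, which is a limit of the assay and not a number. Its reading is thus (the limit of > 10000 nM in this assay, at which 1 of the 2 values shown sits).

Compound 3 `COc1cccc(C2=NN(C(=O)c3ccc(OC)nc3)C(c3cn(C)c4ccc(OC)cc34)C2)c1` keeps the shared core and differs from compound 2 in one group, with 3-methoxyphenyl in place of 4-bromophenyl on a carbon with a double bond to nitrogen. Within the data shown here, one measured step bears on this group: an at least 45-fold higher number from compound 1 to compound 2 (1.65 log units; beyond the scatter). That step is large and beyond the scatter, and it comes from bromo in place of fluoro on an aromatic carbon. Among the measured compounds shown here, it shows that a single change on this aromatic ring can move the number a long way, but no measured compound carries 3-methoxyphenyl. A clear step toward a lower number is therefore expected, though the result may again be only a limit. The estimated change is an at least 5.0-fold lower number from compound 2 to compound 3 (0.69 log units; beyond the scatter). In this assay the estimated value for compound 3 is 2000 nM, with an expected range from 300 nM to 10000 nM.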

Compound 3, concentration for 50% growth inhibition: 190 nM
Estimate against measurement, compound 3: 11-fold (1.02 log units) above; the whole stated range lies above it.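

In this assay, the change at the carbon with a double bond to nitrogen gives an at least 52-fold lower number from compound 2 to compound 3 (1.72 log units; beyond the scatter) and so shows that the loss seen with 4-bromophenyl does not extend to every larger aromatic group at this place, since 3-methoxyphenyl has more heavy atoms than the group it replaces. Set against the 4-fluorophenyl of the first compound, the same group gives a 1.2-fold lower number from compound 1 to compound 3 (0.06 log units; within the scatter) and so cannot be told apart from it, which means this position accepts two quite different substituted phenyl groups with no readable change. The size of the first step stays bounded on one side only, as compound 2 carries a limit of the assay and not a number: the limit of > 10000 nM in this assay, at which 1 of the 3 values shown sits.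

The change from 4-bromophenyl to 3-methoxyphenyl swaps both the substituent and its place on the ring, so the compounds shown cannot say which of the two matters, and a 3-bromophenyl or a 4-methoxyphenyl group would separate them. Going by these compounds, it also remains open how a phenyl ring carrying an amine or a carboxylic acid would read in this assay.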